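Ethoxy to Hydroxy on a Weakly Active Series

This account rests on a few compounds, and the source may have more. Where it says the series, first, only, none or still open, it means among the compounds named here.

Compound 1 `COc1ccc(-c2nc(C)nn2-c2cccc(C(=O)NCCOCc3ccccc3)c2)cc1`: 9340 nM
Compound 2 `CCOc1ccc(-c2nc(CC)nn2-c2cccc(C(=O)NCCCCc3ccccc3)c2)cc1`: 16800 nM

In a functional assay on PANC-1 cells (Homo sapiens), read by microscopy, crystal violet staining and transwell migration, with a stated time of 18 h, in the presence of a further agent that is not named here (a higher number here means a weaker inhibitor, a lower number a stronger inhibitor), compound 2 at 16800 nM lies within the scatter of compound 1 at 9340 nM, so the two cannot be ranked. Both sit in the same broad range, and the data offer nothing finer on which to place compound 2.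

Compound 3 `CCc1nc(-c2ccc(O)cc2)n(-c2cccc(C(=O)NCCCCc3ccccc3)c2)n1`, not yet measured, departs from compound 2 at a single place: hydrogen in place of ethyl on an oxygen on an aromatic ring. Hydrogen stands in place of ethyl on an oxygen on an aromatic ring, so that 4-ethoxyphenyl becomes 4-hydroxyphenyl.

Within the data shown here, no pair of measured compounds shows this change, and the data therefore give no direct guide to its size or direction. With nothing to point either way, no step beyond the scatter is expected in this assay, and the expectation stays anchored on compound 2 at 16800 nM. The expected change is a 1.1-fold lower number from compound 2 to compound 3 (0.05 log units; within the scatter), an estimate that remains within the scatter. For compound 3 the estimated value is 15000 nM, with an expected range from 6000 nM to 40000 nM.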

Compound 3, half-maximal inhibitory concentration: 220 nM
Compound 3: the middle estimate sits 68-fold (1.83 log units) above what was measured; the whole stated range lies above it.
By their numbers in this assay, from the lowest: compound 3; then compounds 1 and 2 (each within the scatter of the next).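

In this assay, among these compounds, replacing the ethyl on the oxygen on the aromatic ring with hydrogen, so that 4-ethoxyphenyl becomes 4-hydroxyphenyl, gives a 76-fold lower number from compound 2 to compound 3 (1.88 log units; beyond the scatter) and is the only step that can be read beyond the scatter. Among the compounds shown here, compound 1 and compound 2 both carry an alkyl group on this oxygen and could not be ranked against each other, so they gave no sign that this position could move the number so far; compound 3 shows that, on the frame of compound 2, removing this ethyl alone is enough to separate it clearly from the weakly active pair. The compounds shown offer no independent measurement that would explain the size of this step.

Going by these compounds, it remains open whether the gain needs the hydroxy itself or would also appear with another group at this place, such as an amine or a carboxylic acid. On these data alone, it is equally open whether the same change would give a step of similar size on the different amide side chain of compound 1, or whether it is tied to the frame of compound 2.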